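This account rests on a few compounds, and the source may have more. Where it says the series, first, only, none or still open, it means among the compounds named here.

Compound 1, `CCCCCCCc1cc(=O)c2cc(C(F)(F)F)ccc2[nH]1`, in a physicochemical assay for solubility, read by HPLC, at pH 7.4 (a higher number here means a more soluble compound, a lower number a less soluble compound), gives < 5000 nM, which is a limit of the assay rather than a number.
Compound 2, `CCCCCOCc1cc(=O)c2cc(C(F)(F)F)ccc2[nH]1`, in this assay gives 15000 nM.
Compound 3, `CCCCCCCc1[nH]c2ccc([N+](=O)[O-])cc2c(=O)c1C(=O)O`, in this assay gives 15000 nM.

Compound 1 and compound 2 share a core and differ in one place: pentyloxy in place of hexyl on a saturated chain carbon bound to an aromatic carbon. That change gave an at least 3.0-fold higher number from compound 1 to compound 2 (0.47 log units; beyond the scatter). Because compound 1 sits at the limit of < 5000 nM in this assay, at which 1 of the 3 values shown sits, only the lower bound of this step is known. Compound 3 has a different core; how it differs from compound 1 is not broken down here. In this assay compound 3 stands level with compound 2.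

Compound 4, `CCCCCOCc1[nH]c2ccc([N+](=O)[O-])cc2c(=O)c1C(=O)O`, is not yet measured. It differs from compound 3 by pentyloxy in place of hexyl on a saturated chain carbon bound to an aromatic carbon, the same change, at the same place, as from compound 1 to compound 2. Because that earlier change gave an at least 3.0-fold higher number from compound 1 to compound 2 (0.47 log units; beyond the scatter), a rise is expected here too, though compound 3 already starts at the value compound 2 reached. The step from compound 3 to compound 4 is expected to be a 2.3-fold higher number from compound 3 to compound 4 (0.37 log units; beyond the scatter). Compound 4 is estimated at 35000 nM, with a likely range from 12000 nM to 100000 nM.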

Compound 4, solubility: 50000 nM
Estimate against measurement, compound 4: 1.4-fold (0.15 log units) below, within the range that was stated.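

In this assay, putting pentyloxy in place of hexyl gave a 3.3-fold higher number from compound 3 to compound 4 (0.52 log units; beyond the scatter), and the same change on the core of compound 1 gave an at least 3.0-fold higher number from compound 1 to compound 2 (0.47 log units; beyond the scatter). The change therefore moved the number the same way on both cores, with both steps beyond the usual scatter, but two pairs set no rule for other cores and do not explain the rise. Whether the step has the same size on both cores cannot be said, because compound 1 gives only a limit and its step has only a lower bound: the limit of < 5000 nM in this assay, at which 1 of the 4 values shown sits.

The compounds shown leave open whether the rise would persist with a different group on this chain, such as an amine in place of the oxygen of pentyloxy or a longer chain that keeps this oxygen. They also leave open what each difference between the two cores does on its own, as no pair shown separates those differences.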